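The compounds below may be only part of what the source reports. "The series", "measured", "known", "first", "only" and "open" are said of these compounds alone.

a functional assay on a cell-free system (plasma) with sterol O-acyltransferase, Soat (Rattus norvegicus) as the target (on this read-out higher numbers stand for an effect only at larger amounts of compound and lower numbers for an effect already at smaller amounts), is the single read-out used for all compounds here. Compound 1 `Cc1cc(C)c(NC(=O)N(Cc2cc(-c3ccccc3)on2)C2CCCCCC2)c(C)c1` reaches only a limit in this assay, > 1 mg/kg, so no number is known for it. Compound 3 `CSc1cc(C)nc(SC)c1NC(=O)N(Cc1ccc(N(C)C)cc1)Cc1cccc(-c2cc[nH]n2)c1` likewise stops at a limit in this assay, < 0.1 mg/kg. Compound 2 `Cc1cc(C)c(NC(=O)N(Cc2ccc(-c3nnc(C)o3)cc2)C2CCCCCC2)c(C)c1` also stands at a limit in this assay, > 0.32 mg/kg. All three values are therefore limits rather than numbers, and compound 2 cannot be ranked against the other two.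

Compound 4 `Cc1cc(C)c(NC(=O)N(Cc2ccc(-c3cc[nH]n3)cc2)C2CCCCCC2)c(C)c1` differs from compound 2 in one place: 1H-pyrazol-3-yl in place of 5-methyl-1,3,4-oxadiazol-2-yl on an aromatic carbon. For the measured compounds named here, no measured pair shows this exact change, so its size has not been observed. Compound 3, which carries a 1H-pyrazol-3-yl group on a different core, sits at the limit < 0.1 mg/kg. The expected step is an at least 1.0-fold lower number from compound 2 to compound 4 (0.02 log units; that floor lies within the scatter), toward an effect at smaller amounts, though compound 3 differs in several other places, which makes this expectation uncertain. For compound 4 the estimate is 0.3 mg/kg, with a range from 0.08 mg/kg to 1.2 mg/kg.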

Compound 4, dose for half-maximal effect: > 1 mg/kg
Compound 4 gave a limit, no number; the forecaster's own chance of this, stated with the estimate: 60%; middle value at least 3.3-fold (0.52 log units) away from the limit.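

Compound 2 and compound 4 both stand at limits rather than numbers, and no step can be read for 1H-pyrazol-3-yl in place of 5-methyl-1,3,4-oxadiazol-2-yl. The compounds shown leave open whether this change shifts the half-maximal dose on this core at all.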